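From Nitro to Carboxy: Expecting Compound 3

A few compounds are considered here, and "the series" means these few. Any claim that something is new, unique, unknown or untested is made for them only; others in the source may bear on it.

In a functional assay on MCF7 cells (Homo sapiens) for cytotoxicity, read by sulforhodamine B assay, with a stated time of 48 h, in the presence of a further agent that is not named here (a higher number here means a weaker inhibitor of growth, a lower number a stronger inhibitor of growth), the results so far are:
- compound 1 `Cc1nn(-c2ccccc2)c(Sc2ccc(-c3nc4cc([N+](=O)[O-])ccc4[nH]3)cc2)c1/C=N/NC(N)=O` gives 60 nM 
- compound 2 `Cc1nn(-c2ccccc2)c(Oc2ccc(-c3nc4cc(C(=O)O)ccc4[nH]3)cc2)c1/C=N/NC(N)=S` reads "not determined" (no result reported) 

Among the compounds with values here, compound 1 is the only compound with a number, so there is nothing yet to rank it against, and compound 2 offers no comparison. Compound 3 `Cc1nn(-c2ccccc2)c(Sc2ccc(-c3nc4cc(C(=O)O)ccc4[nH]3)cc2)c1/C=N/NC(N)=O` keeps the core of compound 1 and swaps a single group (carboxy in place of nitro on an aromatic carbon), with carboxy in place of nitro on an aromatic carbon. Within the data shown here, no measured pair shows what this swap does, so the expectation is a judgement. A moderate move toward a higher number in this assay is expected, somewhat beyond the usual scatter. The expected change is a 2.5-fold higher number from compound 1 to compound 3 (0.40 log units; beyond the scatter) and it remains an estimate. For compound 3 the value is estimated at 150 nM with an expected range (30 nM to 800 nM).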

Compound 3, concentration for 50% growth inhibition: 40 nM
Compound 3: the middle estimate sits 3.8-fold (0.57 log units) above what was measured; the range from low to high includes it.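

In this assay, exchanging the nitro group for carboxy on this aromatic carbon, which turns 5-nitro-1H-benzimidazol-2-yl into 5-carboxy-1H-benzimidazol-2-yl, gives a 1.5-fold lower number from compound 1 to compound 3 (0.18 log units; within the scatter). This first readable pair at this position shows that the exchange leaves the two compounds indistinguishable in this test, so the nitro group is not required here for a result of this size. No measurement at hand explains why these two groups read alike.

As far as these compounds go, a single pair cannot show how much freedom this position allows, so it remains open whether an amine, a methyl ester or a plain hydrogen on the same carbon would also read alike. From the compounds shown here alone, it also remains open whether the same exchange would give a similar result on a core other than that of compound 1.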